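The compounds below may be only part of what the source reports. "The series", "measured", "known", "first", "only" and "open" are said of these compounds alone.

Compound 1 `O=c1nc2ccc(Br)cn2cc1Cc1ccc(Br)cc1`: 870 nM
Compound 2 `CC1(C)OC2O[C@@H](Cc3cn4ccccc4nc3=O)C(OCc3ccccc3)C2O1`: > 1000000 nM

For the measured compounds named here, in a functional assay on SK-N-SH cells (Homo sapiens) for cytotoxicity, read by MTT assay, with a stated time of 24 h (a lower number here means a stronger inhibitor, a higher number a weaker inhibitor), compound 1 gives 870 nM, the only true number so far. For compound 2, > 1000000 nM is a limit of the assay and not a number.

Compound 3 `O=c1nc2ccc(Br)cn2cc1Cc1ccc(Cl)cc1` has not yet been measured. It keeps the core of compound 1 and changes one substituent: chloro in place of bromo on an aromatic carbon. This places chloro in place of bromo on an aromatic carbon, para to a large group.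

Going by the values given here, no measured step covers this swap, so the expectation is weakly founded. In this assay no step beyond the scatter is expected, and no direction is favoured. The estimate therefore stays close to compound 1 at 870 nM.

The expected change is a 1.1-fold higher number from compound 1 to compound 3 (0.06 log units; within the scatter).

Compound 3 is expected at 1000 nM, with an estimated range of 300 nM to 3500 nM.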

Compound 3, half-maximal inhibitory concentration: 940 nM
Compound 3: middle estimate off by 1.1-fold (0.03 log units), on the high side, within the range that was stated.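

For the compounds shown here, at the aromatic carbon para to a large group, this assay gives a 1.1-fold higher number from compound 1 to compound 3 (0.03 log units; within the scatter), the first step that can be read in one place. Chloro and bromo are not told apart at this position, and the swap leaves the number of compound 3 within the scatter of the number of compound 1. Nothing on hand bears on the reason for this result.

The compounds shown leave open whether a group other than a halogen at this position, such as an amine, a carboxylic acid or a longer chain, would also stay within the scatter of compound 1. Going by these compounds, the bromo on the shared core is the same in compound 1 and compound 3, and what replacing it would do also remains open.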